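Chloro for methoxy on the pendant ring: compound 3 to 4

The source may report more compounds than this note shows. Statements on the series, on what has been measured and on what is new or still open speak of the compounds shown alone.

Measured compounds in a functional assay on NCI/ADR-RES cells (Homo sapiens) for inhibition; a higher number here means a weaker inhibitor of growth, a lower number a stronger inhibitor of growth:
- compound 1, `COc1cc(/C=C/C(=O)c2cccc(-n3cc(-c4ccccc4)[nH]c3=O)c2)ccc1O`, gives 2920 nM
- compound 2, `O=C(/C=C/c1cccc(O)c1)c1cccc(-n2cc(-c3ccc(Cl)cc3)[nH]c2=O)c1`, gives 2200 nM
- compound 3, `COc1ccc(-c2cn(-c3cccc(C(=O)/C=C/c4ccc(O)c(OC)c4)c3)c(=O)[nH]2)cc1`, gives 2560 nM

Compound 3 stands second highest of the three numbers. Its nearest neighbour is compound 1, which gives 2920 nM, and the gap between them, a 1.1-fold lower number from compound 1 to compound 3 (0.06 log units; within the scatter), lies within the scatter. Compound 2, with 2200 nM, is also within the scatter of compound 3, so none of the three can be called stronger or weaker than another.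

Compound 4, `COc1cc(/C=C/C(=O)c2cccc(-n3cc(-c4ccc(Cl)cc4)[nH]c3=O)c2)ccc1O`, differs from compound 3 in one place: chloro in place of methoxy on an aromatic carbon, on the six-membered aromatic ring of carbon only, para to a large group, so that a 4-methoxyphenyl becomes a 4-chlorophenyl.

Going by the values given here, only one measured step touches that position, a 1.1-fold lower number from compound 1 to compound 3 (0.06 log units; within the scatter), where methoxy replaced hydrogen and the number barely moved. Compound 2 also carries the chloro group but differs elsewhere too, so its value only shows that a chloro-bearing compound sits in the same range. The step from compound 3 to compound 4 is therefore expected to be small, a 1.1-fold lower number from compound 3 to compound 4 (0.05 log units; within the scatter), no more than the scatter in either direction.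

Compound 4 is thus estimated at 2300 nM in this assay, with a range from 1100 nM to 4800 nM.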

Compound 4, concentration for 50% growth inhibition: 2280 nM
Compound 4: the middle estimate sits 1.0-fold (0.00 log units) above what was measured; the measured number falls inside the stated range.
By their numbers in this assay, from the lowest: compounds 2, 4, 3 and 1 (each within the scatter of the next).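

In this assay, the 4-methoxyphenyl can give way to the 4-chlorophenyl with no change that stands clear of the scatter: a 1.1-fold lower number from compound 3 to compound 4 (0.05 log units; within the scatter). The step with chloro in place of hydrogen on the same aromatic carbon, a 1.3-fold lower number from compound 1 to compound 4 (0.11 log units; within the scatter), is also within the scatter, so hydrogen, methoxy and chloro have now all been read at this place and none of the three stands apart. Going by these compounds alone, with chloro held in place, the change of 3-hydroxyphenyl to 4-hydroxy-3-methoxyphenyl on the double-bonded chain carbon gives the same picture, a 1.0-fold higher number from compound 2 to compound 4 (0.02 log units; within the scatter), which the earlier compounds could not show because none of them formed a single-change pair with a chloro compound.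

No measurement at hand speaks to why these swaps leave the number in one range. On these data alone, whether an amine, a carboxylic acid or a longer chain such as butoxy on this aromatic carbon would move the number beyond the scatter stays open, since the three groups read so far span only small substituents.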